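The source may report more compounds than this note shows. Statements on the series, on what has been measured and on what is new or still open speak of the compounds shown alone.

In an ADME assay on microsomes from liver (Homo sapiens) for metabolic stability, read by LC-MS, using NADPH, with a stated time of 60 min, tested at 0.1 uM (on this read-out lower numbers stand for a less stable compound and higher numbers for a more stable compound), compound 1 (`Fc1ccc(Nc2cc3[nH]c(Nc4cc(N5CCNCC5)ccn4)nc3cn2)cc1C(F)(F)F`) gives 98%, level with compound 3 (`Fc1ccc(Nc2cc3[nH]c(Nc4ccc(C5CCNCC5)cn4)nc3cn2)cc1F`) at 98%. Among the measured compounds shown here, these two share the highest number measured so far, while compound 2 (`C[C@@H]1CN(c2ccc(Nc3nc4cnc(Nc5ccc(F)c(F)c5)cc4[nH]3)nc2)C[C@H](C)N1`) gives 63%. Compound 4 (`C[C@@H]1CN(C(=O)c2ccnc(Nc3nc4cnc(Nc5ccc(F)c(C(F)(F)F)c5)cc4[nH]3)c2)C[C@H](C)O1`) is still unmeasured and carries (2,6-dimethylmorpholin-4-yl)carbonyl in place of piperazin-1-yl on an aromatic carbon. For the measured compounds named here, no measured compound carries this group, so the evidence is indirect. The closest guide is the large step of a number 35 percentage points higher from compound 2 to compound 3 (beyond the scatter), with piperidin-4-yl in place of 3,5-dimethylpiperazin-1-yl, where the dimethyl-substituted ring stands on the lower side. On that basis, a fall of smaller size is expected, estimated as a number 26 percentage points lower from compound 1 to compound 4 (beyond the scatter). For compound 4 the estimated value is 72%, with an expected range from 45% to 95%.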

Compound 4, percent of the compound remaining: 63%
Compound 4: middle estimate off by 9 percentage points, on the high side, within the range that was stated.
By their numbers in this assay, from the lowest: compounds 2 and 4 (each within the scatter of the next); then compounds 1 and 3 (each within the scatter of the next).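

In this assay, the place opposite the ring nitrogen responds strongly to its group: (2,6-dimethylmorpholin-4-yl)carbonyl in place of piperazin-1-yl gives a number 35 percentage points lower from compound 1 to compound 4 (beyond the scatter). Among the earlier compounds, only compound 1 carried a group at this place, so this is the first step that can be read there. Nothing shown here explains the fall.

From the compounds shown here alone, the change replaces the ring and adds a carbonyl at once, so the share of each stays open. An unsubstituted morpholin-4-yl group, or piperazin-1-yl joined through a carbonyl, would help separate them.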